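This account rests on a few compounds, and the source may have more. Where it says the series, first, only, none or still open, it means among the compounds named here.

Compound 3 `COCOc1cccc(C(=O)/C=C/c2ccc3c(c2)B(O)OC3)c1` shares its core with compound 1 `Cc1ccc(C(=O)/C=C/c2ccc3c(c2)B(O)OC3)cc1` and compound 2 `O=C(/C=C/c1ccc2c(c1)B(O)OC2)c1ccccc1`. In an ADME assay on L929 cells (Mus musculus) for cytotoxicity, read by resazurin assay, with a stated time of 72 h (on this read-out higher numbers stand for weaker inhibition and lower numbers for stronger inhibition), compound 3 gives > 10 ug/mL, which is a limit of the assay rather than a number. Compound 1 gives > 10 ug/mL in this assay, again a limit. Compound 2 gives > 10 ug/mL in this assay, also a limit. The steps a step that the two limits leave unreadable from compound 1 to compound 2 and a step that the two limits leave unreadable from compound 2 to compound 3 therefore cannot be sized, since (the limit of > 10 ug/mL in this assay, at which 3 of the 3 values shown sit). Compound 4 `O=C(/C=C/c1ccc2c(c1)B(O)OC2)c1cccc(O)c1` differs from compound 3 by hydrogen in place of methoxymethyl on an oxygen on an aromatic ring. For the measured compounds named here, no measured step bears on this change, and the two steps seen give no readable size. Compound 4 is expected to remain at the limit, a step that the limit leaves unreadable from compound 3 to compound 4. The estimate for compound 4 is 15 ug/mL, between 8 ug/mL and 40 ug/mL.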

Compound 4, half-maximal inhibitory concentration: 7.56 ug/mL
Beside the measured number, compound 4's estimate is 2.0-fold (0.30 log units) above it; measured number below the stated range.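

For the compounds shown here, compound 4, with hydroxy on the aromatic ring, is the only compound here that gives a number rather than a limit in this assay. Hydroxy in place of methoxymethoxy gives an at least 1.3-fold lower number from compound 3 to compound 4 (0.12 log units; that floor lies within the scatter) and hydroxy in place of hydrogen gives an at least 1.3-fold lower number from compound 2 to compound 4 (0.12 log units; that floor lies within the scatter) and 3-hydroxyphenyl in place of 4-methylphenyl gives an at least 1.3-fold lower number from compound 1 to compound 4 (0.12 log units; that floor lies within the scatter). Going by these compounds alone, these are only floors, and neither their true sizes nor the earlier steps can be read because the other compounds stop at a limit: the limit of > 10 ug/mL in this assay, at which 3 of the 4 values shown sit.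

The compounds shown leave open how an amine or a carboxylic acid in place of the hydroxy would read in this assay.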